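The source may report more compounds than this note shows. Statements on the series, on what has been measured and on what is new or still open speak of the compounds shown alone.

Working notes on the series. Of the compounds shown here, two of the shared core have been measured so far: compound 1 `COc1ccc(-c2cc(-c3ccc4c(c3)CCCC4)[nH]c(=O)c2C#N)cc1OC` and compound 2 `CC(C)c1ccc(-c2cc(-c3ccc4c(c3)CCCC4)[nH]c(=O)c2C#N)cc1`. In an ADME assay on RAW264.7 cells (Mus musculus) for cytotoxicity, with a stated time of 24 h (a higher number here means a weaker inhibitor, a lower number a stronger inhibitor), compound 1 gives > 100000 nM, which is a limit of the assay and not a number. Compound 2 likewise gives > 100000 nM in this assay, again a limit. Compound 2 therefore stands at the same limit as the other measured compound, as both values sit at the limit of > 100000 nM in this assay, at which 2 of the 2 values shown sit. The next compound, compound 3 `N#Cc1c(-c2c[nH]c3ccccc23)cc(-c2ccc3c(c2)CCCC3)[nH]c1=O`, differs from compound 2 in one place: 1H-indol-3-yl in place of 4-isopropylphenyl on an aromatic carbon. For the measured compounds named here, no measured step of this kind exists, so the change from 4-isopropylphenyl to 1H-indol-3-yl carries no precedent here. The step from compound 2 to compound 3 is expected to stay within the scatter, with an estimated shift of a number no higher from compound 2 to compound 3 (the limit leaves the size open) in this assay. Compound 3 is thus estimated at 100000 nM in this assay, within a range from 30000 nM to 300000 nM, most likely again reported only as a limit.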

Compound 3, half-maximal inhibitory concentration: > 100000 nM
Compound 3: no number, only a limit; the forecaster's own chance of this, stated with the estimate: 70%; the middle value lies on the limit itself.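

In this assay compound 3 gives > 100000 nM, which is a limit and not a number. The step from compound 2 to compound 3 therefore cannot be read. The compounds shown leave open how far any of them lies from that limit: the limit of > 100000 nM in this assay, at which 3 of the 3 values shown sit.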